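The source may report more compounds than this note shows. Statements on the series, on what has been measured and on what is new or still open speak of the compounds shown alone.

Working notes on the series. Compound 1 `Nc1nc(OCc2ccccc2)c2[nH]c(N)nc2n1` gives 2 uM in an assay on HT-29 cells with Methylated-DNA--protein-cysteine methyltransferase (Homo sapiens) as the target, with a stated time of 4 h; on this read-out lower numbers stand for an effect already at smaller amounts and higher numbers for an effect only at larger amounts of compound. Compound 2 `Cc1nc2[nH]c(N)nc(OCc3ccccc3)c-2n1` gives 0.1 uM in this assay. Compound 3 `Nc1nc(OCc2ccccc2)c2[nH]c(O)nc2n1` gives 0.15 uM in this assay. Among the three numbers measured, compound 3 stands second highest; its nearest neighbour is compound 2, whose value lies within the scatter of that of compound 3, and the furthest is compound 1, reached by the step of a 13-fold lower number from compound 1 to compound 3 (1.12 log units; beyond the scatter).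

The next compound is compound 4 `Nc1nc(OCc2ccccc2)c2[nH]c(Br)nc2n1`, which differs from compound 3 in one place: bromo in place of hydroxy on an aromatic carbon. Among the compounds with values here, the only measured step at this same carbon is the one from compound 1 to compound 3, where exchanging amino for hydroxy gave a large drop in the number. Within the data shown here, no measured pair shows what bromo does on this carbon, and compound 2 differs from the others in more than one place, so it gives no single-point guidance. With the hydrogen-bond donor and acceptor of the hydroxy removed, the direction is open. A modest move towards a higher number than compound 3 is expected, estimated at a 3.3-fold higher number from compound 3 to compound 4 (0.52 log units; beyond the scatter), with wide uncertainty. For compound 4 the estimate in this assay is 0.5 uM, within a range from 0.1 uM to 3 uM.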

Compound 4, concentration for half-maximal effect: 0.06 uM
Compound 4: middle estimate off by 8.3-fold (0.92 log units), on the high side; the measured number lies below the stated range.
By their numbers in this assay, from the lowest: compounds 4, 2 and 3 (each within the scatter of the next, the first and the last beyond it); then compound 1.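

Bromo in place of hydroxy on this aromatic carbon, between two ring nitrogen atoms, gives a 2.5-fold lower number from compound 3 to compound 4 (0.40 log units; beyond the scatter) in this assay and thus shows that a low number here does not depend on the hydrogen-bond donor and acceptor of the hydroxy. Measured against amino, bromo gives a 33-fold lower number from compound 1 to compound 4 (1.52 log units; beyond the scatter) and so goes further than hydroxy, which gave a 13-fold lower number from compound 1 to compound 3 (1.12 log units; beyond the scatter) and the three compounds that differ only at this carbon now fall in the order amino, hydroxy, bromo, from the highest number to the lowest. No available measurement accounts for the effect of bromo at this carbon.

The three groups alone do not separate what the removal of amino contributes from anything particular to bromo, and chloro, methyl, a carboxylic acid or a longer chain on this carbon would be needed to show how far the low numbers extend. Going by these compounds, compound 2 differs from these compounds in more than one place, so whether bromo would have the same effect on its core remains open.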